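Swapping the ring pair on the sugar: tolerance expected unchanged

This account rests on a few compounds, and the source may have more. Where it says the series, first, only, none or still open, it means among the compounds named here.

Measured so far:
Compound 1 `CC(C)(C)[Si](C)(C)OC[C@H]1O[C@@H](n2cnc3cncnc32)[C@H](O[Si](C)(C)C(C)(C)C)[C@]12OS(=O)(=O)C=C2N`: 13000 nM
Compound 2 `CC(C)(C)[Si](C)(C)OC[C@H]1O[C@@H](n2cnc3c(O)ncnc32)[C@H](O[Si](C)(C)C(C)(C)C)[C@]12OS(=O)(=O)C=C2N`: 14000 nM
Compound 3 `CNc1ncnc2c1ncn2[C@@H]1O[C@H](CO[Si](C)(C)C(C)(C)C)[C@@]2(OS(=O)(=O)C=C2N)[C@H]1O[Si](C)(C)C(C)(C)C`: 14000 nM

In a functional assay on MT4 cells (Homo sapiens) for cytotoxicity (a lower number here means that less compound is tolerated, a higher number that more compound is tolerated), compound 1 gives 13000 nM, the lowest of the three numbers, but the three values sit within the scatter of one another, so no order among them can be claimed. The steps of a 1.1-fold higher number from compound 1 to compound 2 (0.03 log units; within the scatter) and a 1.1-fold higher number from compound 1 to compound 3 (0.03 log units; within the scatter) show that changing a hydrogen on an aromatic carbon to hydroxy or to methylamino leaves the tolerated concentration essentially where it was; no change at the digits printed from compound 2 to compound 3 (within the scatter) tells the same between those two.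

Compound 4 `CCn1cnc2ncn([C@@H]3O[C@H](CO[Si](C)(C)C(C)(C)C)[C@@]4(OS(=O)(=O)C=C4N)[C@H]3O[Si](C)(C)C(C)(C)C)c2c1=O` differs from compound 1 in a larger way: a group of 12 heavy atoms (7 carbon, 4 nitrogen, 1 oxygen; one five-membered aromatic ring with 2 hetero atoms, one six-membered aromatic ring with 2 hetero atoms) in place of a group of 9 heavy atoms (5 carbon, 4 nitrogen; one five-membered aromatic ring with 2 hetero atoms, one six-membered aromatic ring with 2 hetero atoms), on a saturated ring carbon. This exchange of the whole two-ring group on a saturated ring carbon is bigger than any of the measured steps, which all touched a single substituent on that group, so the measured steps bear on it only loosely. Still, nothing seen so far moved this assay at all, and no reason in the data points to a shift in either direction. The step of a 1.1-fold higher number from compound 1 to compound 4 (0.03 log units; within the scatter) is therefore expected to stay within the scatter. Compound 4 is estimated at 14000 nM, with a range from 6000 nM to 30000 nM.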

Compound 4, half-maximal cytotoxic concentration: > 150000 nM
Compound 4 gave a limit, no number; the forecaster's own chance of this, stated with the estimate: 15%; middle value at least 10-fold (1.02 log units) from the limit.
By their numbers in this assay, from the lowest: compounds 1, 2 and 3 (each within the scatter of the next). At a limit, above all of these: compound 4.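

In this assay compound 4 reads as a limit, not as a number: the limit of > 150000 nM in this assay, at which 1 of the 4 values shown sits. The group on this saturated ring carbon can therefore shift the tolerated concentration a long way: the exchange gives an at least 11-fold higher number from compound 1 to compound 4 (1.06 log units; beyond the scatter) and an at least 10-fold higher number from compound 2 to compound 4 (1.02 log units; beyond the scatter) and also an at least 10-fold higher number from compound 3 to compound 4 (1.02 log units; beyond the scatter) in this comparison. Compounds 1, 2 and 3 sat within the scatter of one another, so the entering group of 12 heavy atoms, with 1 double bond outside aromatic rings, is the only one shown that moves this read-out, though the data do not tell which part of it matters.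

On these data alone, the true value of compound 4 and so the full size of these steps stay open. As far as these compounds go, how a two-ring group carrying a carboxylic acid or a longer chain would behave on the same carbon also stays open.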